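Benzylamine Replacement on a Diaryl Ether Scaffold

This account rests on a few compounds, and the source may have more. Where it says the series, first, only, none or still open, it means among the compounds named here.

Measured so far:
Compound 1 `COc1cc(Oc2cccc(Nc3ccccc3)c2)cc(OC)c1CNCCNC(C)=O` — 6010 nM
Compound 2 `COc1ccc([C@@H](C)NCc2c(OC)cc(Oc3cccc(Nc4ccccc4)c3)c(OC)c2OC)cc1` — 3500 nM

Of the compounds shown here, two sharing the diaryl ether core have been tested in a functional assay on DLD-1 cells (Homo sapiens) for inhibition, read by MTT assay, with a stated time of 72 h; a lower number here means a stronger inhibitor, a higher number a weaker inhibitor. Compound 1 gives 6010 nM. Compound 2, which carries an arylethylamine in place of the acetamidoethylamine, gives 3500 nM. Within the data shown here, the gap between these two values falls inside the usual scatter of repeat measurements, so neither compound can be ranked ahead of the other on the present evidence, and compound 1 simply sits alongside compound 2 on the only numbers available.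

Compound 3 `COc1cc(Oc2cccc(Nc3ccccc3)c2)cc(OC)c1CNCc1ccc(Br)cc1` has not yet been tested. Compared with compound 1, the change is 4-bromophenyl in place of acetamidomethyl on a saturated chain carbon bound to an amine nitrogen. Among the measured compounds shown here, no measured pair shows this exact step, so its size is not known from the data. Given that compound 2, carrying an aryl group on the amine side, gives 3500 nM, compound 3 is expected to come in with a modestly lower number than compound 1, a step of a 2.0-fold lower number from compound 1 to compound 3 (0.30 log units; within the scatter) in this assay, though a result within the scatter would not be surprising. Compound 3 is estimated at 3000 nM, with a likely range of 1000 nM to 9000 nM.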

Compound 3, half-maximal inhibitory concentration: 3520 nM
Compound 3: the middle estimate sits 1.2-fold (0.07 log units) below what was measured, and the stated range covers the measured number.
By their numbers in this assay, from the lowest: compounds 2, 3 and 1 (each within the scatter of the next).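

In this assay, putting 4-bromophenyl in place of acetamidomethyl on a saturated chain carbon bound to an amine nitrogen gives a 1.7-fold lower number from compound 1 to compound 3 (0.23 log units; within the scatter). Among these compounds, this is the first direct reading at this place on the shared core, and it shows that an exchange of an open-chain amide for a six-membered aromatic ring, with its hydrogen-bond donor and acceptor gone, leaves the number within the scatter. No measurement here bears on why the two groups read alike.

The compounds shown leave open whether the bromine matters at all, since a plain phenyl or a 4-chlorophenyl group does not appear among them. They also leave open whether a carboxylic acid, a free primary amine or a longer chain at this place would give a step beyond the scatter.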